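Cytotoxicity notes: aminoalkylamino variants on a shared core

This account rests on a few compounds, and the source may have more. Where it says the series, first, only, none or still open, it means among the compounds named here.

Measured compounds:
Compound 1 `Cc1ccc2nc(N3CCCc4ccc(F)cc4C3)cc(NCC3(N)COC3)c2c1`. In an ADME assay on HEp-2 cells (Homo sapiens) for cytotoxicity, read by CCK-8 assay, with a stated time of 5 days (on this read-out higher numbers stand for lower toxicity in this test and lower numbers for higher toxicity in this test), compound 1 gives > 100000 nM; that value is a limit of the assay and not a number.
Compound 2 `Cc1ccc2nc(N3CCCc4ccc(F)cc4C3)cc(NCC(C)N)c2c1`. In this assay compound 2 gives 86000 nM.

Going by the values given here, compound 2 holds the only numerical value in this assay; the other value shown is a limit. Compound 1 sits at the limit of > 100000 nM in this assay, at which 1 of the 2 values shown sits. Among the compounds with values here, the one measured step, an at least 1.1-fold lower number from compound 1 to compound 2 (0.06 log units; that floor lies within the scatter), replaces 3-aminooxetan-3-yl with 1-aminoethyl on a saturated chain carbon bound to a nitrogen on an aromatic ring, and its floor lies within the scatter.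

Compound 3 `Cc1ccc2nc(N3CCCc4ccc(F)cc4C3)cc(NC(C)(C)CN)c2c1` differs from compound 2 by 1-(aminomethyl)-1-methylethyl in place of 2-aminopropyl on a nitrogen on an aromatic ring. Within the data shown here, this is a rearrangement of the same short aminoalkyl chain on the same nitrogen, and the only step measured on this part of the molecule did not move beyond the scatter. A step of no more than the scatter is therefore expected, with no direction favoured. Compound 3 is estimated at 90000 nM, range 40000 nM to 200000 nM. The expected step is a 1.0-fold higher number from compound 2 to compound 3 (0.02 log units; within the scatter), and the value may again come out as a limit.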

Compound 3, half-maximal cytotoxic concentration: 25000 nM
For compound 3 the middle estimate is 3.6-fold (0.56 log units) above the measured one; the whole stated range lies above it.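

In this assay, the substituent on the nitrogen on an aromatic ring can move the read-out beyond the scatter: 1-(aminomethyl)-1-methylethyl in place of 2-aminopropyl gives a 3.4-fold lower number from compound 2 to compound 3 (0.54 log units; beyond the scatter), which on this read-out means higher toxicity in this test. With 5 heavy atoms entering and 4 leaving, this change is more than a rearrangement of the same chain, and the replacement of (3-aminooxetan-3-yl)methyl by the same group gives an at least 4.0-fold lower number from compound 1 to compound 3 (0.60 log units; beyond the scatter), a step also beyond the scatter, whereas the earlier step's floor stayed within it. Compound 1 remains a limit of the assay and not a number: the limit of > 100000 nM in this assay, at which 1 of the 3 values shown sits.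

The compounds shown do not separate the effect of the extra carbon from that of its arrangement in the chain, and a single pair with a numerical value is a narrow base for any trend at this position. A plain 2-aminoethyl chain, a longer chain such as 3-aminopropyl, or a dimethylamino group in place of the primary amine would show whether the step extends beyond these three compounds.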